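This account rests on a few compounds, and the source may have more. Where it says the series, first, only, none or still open, it means among the compounds named here.

Of the compounds shown here, three have numbers so far in a functional assay on A549 cells (Homo sapiens) for antiproliferative activity, read by MTT assay, with a stated time of 48 h; a higher number here means a weaker inhibitor, a lower number a stronger inhibitor. Compound 1 (`COc1ccc(/C=C/c2cc(OC)cc(OC)c2/C=C/C(=O)c2cccc(Br)c2)cc1`) gives 8.1 ug/mL. Compound 2 (`CCCCCCOc1ccc(C(=O)/C=C/c2c(/C=C/c3ccc(OC)cc3)cc(OC)cc2OC)cc1`) gives 8.4 ug/mL. Compound 3 (`COc1ccc(/C=C/c2cc(OC)cc(OC)c2/C=C/C(=O)c2ccc(Cl)cc2)cc1`) gives 6.4 ug/mL. The steps that reach compound 3 are a 1.3-fold lower number from compound 1 to compound 3 (0.10 log units; within the scatter) and a 1.3-fold lower number from compound 2 to compound 3 (0.12 log units; within the scatter), so the three numbers cannot be ranked and compound 3 stands level with the other two.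

Compound 4 (`COc1ccc(/C=C/c2cc(OC)cc(OC)c2/C=C/C(=O)c2ccccc2)cc1`) has no number yet in this assay. The change is hydrogen in place of chloro on an aromatic carbon, which is hydrogen in place of chloro on an aromatic carbon, para to a large group.

For the measured compounds named here, two measured steps bear on this change, as both alter the group on the same carbonyl carbon. One puts 4-chlorophenyl in place of 3-bromophenyl, and the other puts chloro in place of hexyloxy. Neither tests hydrogen at this place, so the support is indirect. Both stayed within the scatter, as shown by a 1.3-fold lower number from compound 1 to compound 3 (0.10 log units; within the scatter) and a 1.3-fold lower number from compound 2 to compound 3 (0.12 log units; within the scatter), and no step beyond the scatter is therefore expected, in either direction. The expected step is a 1.2-fold higher number from compound 3 to compound 4 (0.07 log units; within the scatter). Compound 4 is estimated at 7.5 ug/mL, with an expected range from 4 ug/mL to 14 ug/mL.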

Compound 4, half-maximal inhibitory concentration: 3.9 ug/mL
For compound 4 the middle estimate is 1.9-fold (0.28 log units) above the measured one; the measured number lies below the stated range.
By their numbers in this assay, from the lowest: compounds 4, 3, 1 and 2 (each within the scatter of the next, the first and the last beyond it).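

In this assay, for the compounds shown here, the steps to the phenyl of compound 4 give the first separations in this small set: a 2.1-fold lower number from compound 1 to compound 4 (0.32 log units; beyond the scatter) and a 2.2-fold lower number from compound 2 to compound 4 (0.33 log units; beyond the scatter), both modest, while the single change of chloro to hydrogen gives a 1.6-fold lower number from compound 3 to compound 4 (0.22 log units; within the scatter). Hydrogen at this place, para to a large group, therefore keeps the number level with the 4-chlorophenyl of compound 3 and clear of the 3-bromophenyl of compound 1 and the hexyloxy group of compound 2, so no substituent on this ring is needed for a number in this range. Nothing at hand accounts for these differences.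

From the compounds shown here alone, whether an amine, a carboxylic acid or a longer chain than hexyloxy on this aromatic carbon would stay level with compound 4 remains open. A 4-bromophenyl group would also be needed to separate the identity of the halogen from its place, since the 3-bromophenyl of compound 1 and the 4-chlorophenyl of compound 3 differ in both.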